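This account rests on a few compounds, and the source may have more. Where it says the series, first, only, none or still open, it means among the compounds named here.

Compound 3 `COC(=O)/C=C/c1cccc(N(Cc2ccc(/C=C/C(=O)O)cc2)C(=O)C2CCCCC2)c1` gives 1000 nM in an assay on isolated protein with Bile acid receptor (Homo sapiens) as the target; a higher number here means that more compound is needed for the effect, a lower number that less compound is needed. Compound 1 `CC(C)(C)OC(=O)/C=C/c1ccc(CN(C(=O)C2CCCCC2)c2cccc(/C=C/C(=O)OC(C)(C)C)c2)cc1` gives 1000 nM in this assay, level with compound 3 at the digits shown, and together these two are the highest of the three numbers. Compound 2 `COC(=O)/C=C/c1cccc(N(Cc2cc(OC)cc(OC)c2)C(=O)C2CCCCC2)c1` gives 603 nM in this assay, and the step of a 1.7-fold higher number from compound 2 to compound 3 (0.22 log units; within the scatter) lies within the scatter, so the three measured compounds cannot be placed in any order on this assay.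

Compound 4 `COC(=O)/C=C/c1cccc(N(Cc2ccc(/C=C/c3c(Cl)cccc3Cl)cc2)C(=O)C2CCCCC2)c1` differs from compound 3 in a single place: 2,6-dichlorophenyl in place of carboxy on a double-bonded chain carbon bound to a double-bonded chain carbon. Going by the values given here, the one measured step, from compound 2 to compound 3, exchanged the aryl group on the saturated chain carbon and left the number essentially unchanged; it says nothing about exchanging the carboxy at the end of the ethenyl chain for an aryl ring. Among the compounds with values here, no measured pair bears directly on the change from compound 3 to compound 4, so the expectation rests on the absence of any large movement across the three compounds so far. On that basis one expects the step of a 1.7-fold lower number from compound 3 to compound 4 (0.22 log units; within the scatter) in this assay to be modest, most likely toward a somewhat lower number but with wide uncertainty. The estimate for compound 4 in this assay is 600 nM, with a range from 150 nM to 2500 nM.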

Compound 4, half-maximal effective concentration: 151 nM
The estimate for compound 4 lay 4.0-fold (0.60 log units) above the measured number, and the stated range covers the measured number.
By their numbers in this assay, from the lowest: compound 4; then compounds 2, 1 and 3 (each within the scatter of the next).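

In this assay, the exchange of 2-carboxyethenyl for 2-(2,6-dichlorophenyl)ethenyl gives a 6.6-fold lower number from compound 3 to compound 4 (0.82 log units; beyond the scatter), the only step among these compounds that lies beyond the scatter, whereas exchanging the aryl group on the saturated chain carbon gave a 1.7-fold higher number from compound 2 to compound 3 (0.22 log units; within the scatter). The place on a double-bonded chain carbon bound to a double-bonded chain carbon is thus one where the number responds to the group carried, and the carboxy, with its hydrogen-bond donor, is not required for the lower number, since a larger group with no hydrogen-bond donor or acceptor gives that number in its stead. Nothing available accounts for the size or direction of this step.

Because the carboxy leaves while the aromatic ring and its two chlorine atoms enter in one exchange, the compounds shown cannot separate the contribution of the ring from that of the chlorine atoms or from the loss of the carboxy. Going by these compounds, an unsubstituted phenyl, a phenyl with a single chlorine, or an amine at this place would bear on that question, and whether the step carries over to other groups on the shared core remains open.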